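Urea series: chloro to trifluoromethyl on the aryl urea

The source may report more compounds than this note shows. Statements on the series, on what has been measured and on what is new or still open speak of the compounds shown alone.

Measured compounds:
compound 1 `COc1cc(-c2nn(-c3cccc(NC(=O)Nc4cc(C(F)(F)F)cc(C(F)(F)F)c4)c3)cc2-c2ccncc2)ccc1Cl` — 2910 nM
compound 2 `COc1cc(-c2nn(-c3cccc(NC(=O)Nc4ccc(Cl)c(Cl)c4)c3)cc2-c2ccncc2)ccc1Cl` — 3140 nM
compound 3 `O=C(Nc1cccc(-n2cc(-c3ccncc3)c(-c3ccc(Cl)c(O)c3)n2)c1)Nc1ccc(Cl)c(Cl)c1` — 22700 nM

Of the three measured in a functional assay on COLO 205 cells (Homo sapiens) for inhibition, read by sulforhodamine B assay, with a stated time of 48 h (on this read-out lower numbers stand for higher toxicity in this test and higher numbers for lower toxicity in this test), compound 2 gives 3140 nM, second highest of the three. Compound 1 gives 2910 nM, which lies within the scatter of compound 2. Within the data shown here, compound 3 gives 22700 nM, and the step of a 7.2-fold higher number from compound 2 to compound 3 (0.86 log units; beyond the scatter) arises from hydrogen in place of methyl on an oxygen on an aromatic ring; it is the only step on record that changes one place, and it lies on the other side of the molecule from the change considered here.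

Compound 4 `COc1cc(-c2nn(-c3cccc(NC(=O)Nc4ccc(Cl)c(C(F)(F)F)c4)c3)cc2-c2ccncc2)ccc1Cl` differs from compound 2 by trifluoromethyl in place of chloro on an aromatic carbon, that is, 3,4-dichlorophenyl to 4-chloro-3-(trifluoromethyl)phenyl on the urea. Among the measured compounds shown here, no single step of this kind has been measured. The nearest guidance is that compound 1, carrying two trifluoromethyl groups on that ring, and compound 2, carrying two chloro groups, give numbers within the scatter of one another. A step of a 1.0-fold lower number from compound 2 to compound 4 (0.02 log units; within the scatter) is therefore expected, no larger than the scatter. Compound 4 is estimated at 3000 nM, within 1500 nM to 6500 nM.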

Compound 4, concentration lethal to 50% of the cells: 3480 nM
Beside the measured number, compound 4's estimate is 1.2-fold (0.06 log units) below it; the measured number falls inside the stated range.
By their numbers in this assay, from the lowest: compounds 1, 2 and 4 (each within the scatter of the next); then compound 3.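

In this assay, trifluoromethyl in place of chloro on an aromatic carbon, ortho to a chloro group, now has a direct one-place reading. Among these compounds, the step of a 1.1-fold higher number from compound 2 to compound 4 (0.04 log units; within the scatter) shows that, at this position and with the chloro group retained, this exchange leaves the number within the scatter, which the earlier compounds could not show because none of their steps isolates this change. No measurement given here accounts for this result.

Still open, going by these compounds, is whether a group of another kind at this position, such as an amine, a nitrile or a carboxylic acid, would give a step beyond the scatter. Also open, on these data alone, is whether the same exchange would read alike on compound 3, which carries hydrogen in place of methyl on an oxygen on an aromatic ring.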